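This account rests on a few compounds, and the source may have more. Where it says the series, first, only, none or still open, it means among the compounds named here.

In a functional assay on SNU-638 cells (Homo sapiens) for cytotoxicity, read by sulforhodamine B assay, with a stated time of 72 h (a higher number here means a weaker inhibitor, a lower number a stronger inhibitor), the measured compounds are:

compound 1 `CCS(=O)(=O)Nc1cc(-c2ccc3ncnc(Nc4ccc(OC)c(Cl)c4)c3c2)cnc1OC`: 3620 nM
compound 2 `CCS(=O)(=O)Nc1cc(-c2ccc3ncnc(Nc4ccc(Cl)c(C(=O)OC)c4)c3c2)cnc1OC`: 2200 nM
compound 3 `CCS(=O)(=O)Nc1cc(-c2ccc3ncnc(Nc4ccc(C(=O)OC)c(OC)c4)c3c2)cnc1OC`: 3440 nM

Compound 3 stands second highest of the three numbers, nearest to compound 1 and furthest from compound 2, yet every gap is within the scatter: a 1.1-fold lower number from compound 1 to compound 3 (0.02 log units; within the scatter) and a 1.6-fold higher number from compound 2 to compound 3 (0.19 log units; within the scatter). Compound 4 `CCS(=O)(=O)Nc1cc(-c2ccc3ncnc(Nc4ccc(OC)nc4)c3c2)cnc1OC` differs from compound 3 by 6-methoxypyridin-3-yl in place of 3-methoxy-4-(methoxycarbonyl)phenyl on a nitrogen on an aromatic ring. All three measured steps bear on this change, since each swaps the group on that same nitrogen: a 1.6-fold lower number from compound 1 to compound 2 (0.22 log units; within the scatter), a 1.1-fold lower number from compound 1 to compound 3 (0.02 log units; within the scatter) and a 1.6-fold higher number from compound 2 to compound 3 (0.19 log units; within the scatter), none beyond the scatter. The expected step from compound 3 to compound 4 is therefore a 1.0-fold lower number from compound 3 to compound 4 (0.01 log units; within the scatter), no movement beyond the scatter. Compound 4 is estimated at 3400 nM, in a range from 1500 nM to 8000 nM.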

Compound 4, half-maximal inhibitory concentration: 4280 nM
Beside the measured number, compound 4's estimate is 1.3-fold (0.10 log units) below it, within the range that was stated.
By their numbers in this assay, from the lowest: compounds 2, 3, 1 and 4 (each within the scatter of the next).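

In this assay, the 6-methoxypyridin-3-yl group, alone among these groups in having a hetero atom in its six-membered aromatic ring, stays within the scatter of all three earlier compounds (a 1.2-fold higher number from compound 3 to compound 4 (0.09 log units; within the scatter)) (a 1.9-fold higher number from compound 2 to compound 4 (0.29 log units; within the scatter)) (a 1.2-fold higher number from compound 1 to compound 4 (0.07 log units; within the scatter)). On this nitrogen, then, a ring with a hetero atom and no chloro or methoxycarbonyl substituent still produces no step beyond the scatter. Nothing measured here accounts for this flat result.

As far as these compounds go, it remains open whether any group at this place can move the number beyond the scatter. An amine or a carboxylic acid on this ring, for instance, would test that.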